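Swapping the Benzyl Arm for an Ethylphenyl Ring

The source may hold more compounds than are shown below. What is called first, only, known or untested is meant among the compounds shown, and "the series" means these compounds.

Compound 1 `Cc1ccc(Nc2ncc(Cl)c(Nc3ccccc3C)n2)cc1` and compound 2 `CN1CCN(c2ccc(Nc3ncc(Cl)c(NCc4ccc(C(F)(F)F)cc4)n3)nc2)CC1` were both tested in an ADME assay on L02 cells (Homo sapiens) for inhibition, read by CCK-8 assay, with a stated time of 48 h; a lower number here means a stronger inhibitor of growth, a higher number a weaker inhibitor of growth. Compound 1 gives only a limit there, > 100000 nM. That value of compound 1 is a limit of the assay (the limit of > 100000 nM in this assay, at which 1 of the 2 values shown sits). Among the measured compounds shown here, compound 2 gives 26200 nM, the only real number among the two values. Compound 3 `CCc1ccc(Nc2nc(Nc3ccc(N4CCN(C)CC4)cn3)ncc2Cl)cc1` has not been measured. It differs from compound 2 by 4-ethylphenyl in place of 4-(trifluoromethyl)benzyl on a nitrogen on an aromatic ring. For the measured compounds named here, no measured step of this kind exists, so the expected change is modest, a 1.5-fold lower number from compound 2 to compound 3 (0.16 log units; within the scatter), leaning towards slightly stronger growth inhibition but not beyond the usual scatter. Compound 3 is therefore estimated at 18000 nM in this assay, with a range from 6000 nM to 55000 nM.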

Compound 3, concentration for 50% growth inhibition: 12100 nM
Estimate against measurement, compound 3: 1.5-fold (0.17 log units) above, within the range that was stated.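

In this assay, the group on this nitrogen affects the result: 4-ethylphenyl in place of 4-(trifluoromethyl)benzyl gives a 2.2-fold lower number from compound 2 to compound 3 (0.34 log units; beyond the scatter). This single change alters two features at once, removing the benzyl link and replacing trifluoromethyl with ethyl, so neither can be credited alone. Nothing measured here gives a reason for the step. Still open, on these data alone, is how each feature contributes alone, as an unsubstituted benzyl or phenyl group would begin to show. Also open, as far as these compounds go, is whether a phenyl ring carrying an amine or a carboxylic acid would move the number further.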